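From isopropyl to methyl: expectation for compound 4

A few compounds are considered here, and "the series" means these few. Any claim that something is new, unique, unknown or untested is made for them only; others in the source may bear on it.

In a functional assay on Bel-7402 cells (Homo sapiens) for antiproliferative activity, read by MTT assay, with a stated time of 72 h (a higher number here means a weaker inhibitor, a lower number a stronger inhibitor), compound 3 (`COc1cccc(CNCc2c(C(=O)O)n(Cc3ccccc3)c3cc(C(C)C)ccc23)c1`) gives 5900 nM as its value. Compound 1 (`COc1cccc(CNCc2c(C(=O)O)n(Cc3ccc(C)cc3)c3cc(C)ccc23)c1`) gives 5670 nM as its value, within the scatter of compound 3. Compound 2 (`COc1cccc(CNCc2c(C(=O)O)n(Cc3ccccc3F)c3cc(C)ccc23)c1`) gives > 50000 nM as its reading, which is a limit and not a number.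

Compound 4 (`COc1cccc(CNCc2c(C(=O)O)n(Cc3ccccc3)c3cc(C)ccc23)c1`) follows from compound 3 by methyl in place of isopropyl on an aromatic carbon. Compound 4 shares that methyl with compound 1 and compound 2.

Within the data shown here, no measured step covers this carbon. Among the measured compounds shown here, the one measured step is an at least 8.8-fold higher number from compound 1 to compound 2 (0.94 log units; beyond the scatter) and it sits on the saturated chain carbon bound to an aromatic nitrogen, not at the changed carbon. It bears only indirectly, as a sign that one change can move the numbers in this series, and so it widens the expected range without setting a direction.

With compound 1 at 5670 nM and carrying the same methyl, no shift beyond the scatter is expected in this assay from this change. The expected step is a 1.1-fold higher number from compound 3 to compound 4 (0.04 log units; within the scatter) and its direction is not firmly set. For compound 4 the estimated value is 6500 nM with an expected range of 1800 nM to 25000 nM as the working figures.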

Compound 4, half-maximal inhibitory concentration: 12500 nM
Beside the measured number, compound 4's estimate is 1.9-fold (0.28 log units) below it, within the range that was stated.
By their numbers in this assay, from the lowest: compounds 1 and 3 (each within the scatter of the next); then compound 4. At a limit, above all of these: compound 2.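

In this assay this aromatic carbon is not silent: methyl in place of isopropyl gives a 2.1-fold higher number from compound 3 to compound 4 (0.33 log units; beyond the scatter), a modest step but one printed beyond the scatter, with isopropyl on the side of the lower number. With methyl held at this carbon, the group on the saturated chain bound to the aromatic nitrogen also registers, as hydrogen in place of methyl gives a 2.2-fold higher number from compound 1 to compound 4 (0.34 log units; beyond the scatter) and hydrogen in place of fluoro gives an at least 4.0-fold lower number from compound 2 to compound 4 (0.60 log units; beyond the scatter), so the unsubstituted phenyl of compound 4 lies between 4-methylphenyl and 2-fluorophenyl in this small set. The reading of compound 2 is a limit and not a number, so its step has a floor and no exact size: the limit of > 50000 nM in this assay, at which 1 of the 4 values shown sits.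

A single pair at this carbon sets no trend with chain size, and hydrogen, tert-butyl, methoxy or a carboxylic acid there would show whether the numbers keep following the size of the group. From the compounds shown here alone, whether isopropyl keeps its step when 4-methylphenyl or 2-fluorophenyl sits on the chain also remains open.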